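Series notes: cap change on the ring amine nitrogen

A few compounds are considered here, and "the series" means these few. Any claim that something is new, unique, unknown or untested is made for them only; others in the source may bear on it.

Compound 1 `Cc1cc(C#N)cc(C)c1Oc1ccnc(Nc2ccc(CN3CCN(S(=O)(=O)C4CC4)CC3)cc2)n1` holds the smaller of the two numbers in an ADME assay on MT4 cells (Homo sapiens) for cytotoxicity, read by MTT assay (a lower number here means that less compound is tolerated, a higher number that more compound is tolerated), where compound 1 gives 4430 nM. Compound 2 `Cc1cc(/C=C/C#N)cc(C)c1Oc1ccnc(Nc2ccc(CN3CCCN(S(=O)(=O)C(C)C)CC3)cc2)n1` in this assay gives 4640 nM, which sits within the scatter of compound 1, so the two cannot be told apart. Compound 3 `C=CC(=O)N1CCN(Cc2ccc(Nc3nccc(Oc4c(C)cc(C#N)cc4C)n3)cc2)CC1` awaits measurement; it differs from compound 1 by vinylcarbonyl in place of cyclopropylsulfonyl on an amine nitrogen in a ring. Among the compounds with values here, no measured pair covers this change, so the expected step of a 1.5-fold lower number from compound 1 to compound 3 (0.17 log units; within the scatter) is taken as modest, toward a lower number, and may not exceed the scatter. Compound 3 is estimated at 3000 nM in this assay, with a range from 1000 nM to 9000 nM.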

Compound 3, half-maximal cytotoxic concentration: 7580 nM
For compound 3 the middle estimate is 2.5-fold (0.40 log units) below the measured one; the measured number falls inside the stated range.
By their numbers in this assay, from the lowest: compounds 1, 2 and 3 (each within the scatter of the next).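

In this assay, within the data shown here, vinylcarbonyl in place of cyclopropylsulfonyl on an amine nitrogen in a ring gives a 1.7-fold higher number from compound 1 to compound 3 (0.23 log units; within the scatter) and is the only measured pair for this position. The two caps therefore cannot be told apart here, although one carries a sulfonyl and a three-membered ring and the other a carbonyl and no ring. Nothing on hand accounts for this result.

Open, going by these compounds, is whether a saturated propanoyl cap, a plain acetyl or a basic alkyl amine on this nitrogen also stays within the scatter of compound 1. Also open, on these data alone, is whether a longer chain on the carbonyl does so.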